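Swapping pyrrolidin-1-yl for morpholin-4-yl on compound 2

A few compounds are considered here, and "the series" means these few. Any claim that something is new, unique, unknown or untested is made for them only; others in the source may bear on it.

Values in an ADME assay on HeLa cells (Homo sapiens) for cytotoxicity, read by MTT assay; on this read-out higher numbers stand for weaker inhibition and lower numbers for stronger inhibition:
Compound 1 `COc1ccc(C[C@H]2COC(=O)[C@@H]2Cc2ccc(OC(=O)CCC(=O)N3CCCC3)c(OC)c2)cc1OC`: 201000 nM
Compound 2 `COc1ccc(C[C@H]2COC(=O)[C@@H]2Cc2ccc(OCC(=O)N3CCCC3)c(OC)c2)cc1OC`: >= 600000 nM

Compound 2 has no exact number. Its entry, >= 600000 nM, is only a limit of the assay.

Compound 3 `COc1ccc(C[C@H]2COC(=O)[C@@H]2Cc2ccc(OCC(=O)N3CCOCC3)c(OC)c2)cc1OC` keeps the rest of compound 2 and makes one change: morpholin-4-yl in place of pyrrolidin-1-yl on a carbonyl carbon. In words, morpholin-4-yl replaces pyrrolidin-1-yl on a carbonyl carbon.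

Within the data shown here, only one measured step is available, an at least 2.9-fold higher number from compound 1 to compound 2 (0.47 log units; beyond the scatter). It changed a different part of the molecule, the group on an oxygen on an aromatic ring, and both of its compounds carry pyrrolidin-1-yl. Among the measured compounds shown here, it therefore offers only weak guidance, and no measured step tests this swap. No shift beyond the scatter is expected in this assay, and compound 3 may well report only a limit too.

The expected change is a number no higher from compound 2 to compound 3 (the limit leaves the size open).

Compound 3 is estimated at 600000 nM, with an expected range of 300000 nM to 1000000 nM.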

Compound 3, half-maximal inhibitory concentration: >= 600000 nM
Compound 3: no number, only a limit; the forecaster's own chance of this, stated with the estimate: 70%; the middle value sits exactly at the limit.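

In this assay, compound 3 gives only a limit, >= 600000 nM, so the step from compound 2 cannot be read and the swap of pyrrolidin-1-yl for morpholin-4-yl has no measurable size. The comparison with the older ester-linked compound can still be read, and it gives an at least 2.9-fold higher number from compound 1 to compound 3 (0.47 log units; beyond the scatter). This shows that a second ring on this carbonyl carbon, morpholin-4-yl, also leaves the read-out at the limit of the assay: the limit of >= 600000 nM in this assay, at which 2 of the 3 values shown sit.

From the compounds shown here alone, whether compound 2 and compound 3 truly differ stays open, as neither has an exact number. The compounds shown also leave open what a piperidin-1-yl ring or a dimethylamino group on this carbonyl carbon would give, or a carboxylic acid in place of the amide.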